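The source may report more compounds than this note shows. Statements on the series, on what has been measured and on what is new or still open speak of the compounds shown alone.

Measured so far:
compound 1, `COc1ccccc1/C=c1/[nH]c(=O)/c(=C\c2ccccc2OC)n(C)c1=O`, in a functional assay on MCF7 cells (Homo sapiens) for cytotoxicity, read by CCK-8 assay, with a stated time of 72 h (a higher number here means a weaker inhibitor, a lower number a stronger inhibitor), compound 1 gives 9000 nM
compound 2, `C=CCn1c(=O)/c(=C\c2cccc(F)c2)[nH]c(=O)/c1=C\c1ccccc1OC`, compound 2 gives 13700 nM
compound 3, `C=CCn1c(=O)/c(=C\c2cccc(Br)c2)[nH]c(=O)/c1=C\c1ccccc1OC`, compound 3 gives 5400 nM

Compound 2 stands at the top of the three numbers as they appear, but compound 1 sits within the scatter of it, and only compound 3 lies beyond it. Compound 4, `C=CCn1c(=O)/c(=C\c2ccc(F)c(Br)c2)[nH]c(=O)/c1=C\c1ccccc1OC`, is not yet measured; it differs from compound 2 by 3-bromo-4-fluorophenyl in place of 3-fluorophenyl on a double-bonded chain carbon bound to an aromatic carbon. Among the compounds with values here, the one measured step that bears on this is a 2.5-fold lower number from compound 2 to compound 3 (0.40 log units; beyond the scatter), also a bromo in place of fluoro on the same ring. Compound 4 carries a bromine on that ring as compound 3 does, while keeping a fluorine, so a step of similar size and direction is expected. For compound 4 the expected value in this assay is 6000 nM (range 2500 nM to 14000 nM), an expected step of a 2.3-fold lower number from compound 2 to compound 4 (0.36 log units; beyond the scatter).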

Compound 4, half-maximal inhibitory concentration: "not active" (no number reported)
Compound 4: no number reported; there is nothing to compare the estimate with.
By their numbers in this assay, from the lowest: compounds 3, 1 and 2 (each within the scatter of the next, the first and the last beyond it).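

Within the data shown here, compound 4 is reported as not active in this assay and carries no number, so no step from compound 2 to compound 4 can be read. The compounds shown leave open how 3-bromo-4-fluorophenyl compares numerically with 3-fluorophenyl. No evidence bears on this result.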